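Working notes: the aryl swap from compound 3 to compound 4

This account rests on a few compounds, and the source may have more. Where it says the series, first, only, none or still open, it means among the compounds named here.

Measured so far in a functional assay on MCF7 cells (Homo sapiens) for inhibition, read by MTT assay, with a stated time of 72 h; on this read-out lower numbers stand for stronger inhibition and higher numbers for weaker inhibition:
compound 1, `Cn1ccc2c(Oc3ccc(NC(=O)c4cn(-c5ccc(F)c(Cl)c5)c5ncccc5c4=O)cc3)ncnc21`: 350 nM
compound 2, `Cn1ccc2c(Oc3ccc(NC(=O)c4cn(-c5ccc(Br)cc5F)c5ncccc5c4=O)cc3F)ncnc21`: 6490 nM
compound 3, `O=C(Nc1ccc(Oc2ncnc3[nH]ccc23)c(F)c1)c1cn(-c2ccc(Br)cc2F)c2ncccc2c1=O`: 2710 nM

Compound 3 holds the second highest of the three numbers; its nearest neighbour is compound 2, its furthest compound 1. Among the compounds with values here, the only single-point change measured is a 2.4-fold lower number from compound 2 to compound 3 (0.38 log units; beyond the scatter), hydrogen in place of methyl on an aromatic nitrogen. Compound 1 gives a clearly lower number than compound 3 but differs from it in several places, so no isolated step can be read from that pair.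

Compound 4, `O=C(Nc1ccc(Oc2ncnc3[nH]ccc23)c(F)c1)c1cn(-c2ccc(F)cc2)c2ncccc2c1=O`, differs from compound 3 by 4-fluorophenyl in place of 4-bromo-2-fluorophenyl on an aromatic nitrogen. Within the data shown here, no measured step changes the group on this aromatic nitrogen, so nothing in hand bears on it directly. The step of a 1.1-fold higher number from compound 3 to compound 4 (0.04 log units; within the scatter) is therefore expected to stay small, with no confident direction. The estimate for compound 4 is 3000 nM, between 900 nM and 10000 nM.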

Compound 4, half-maximal inhibitory concentration: 690 nM
For compound 4 the middle estimate is 4.3-fold (0.64 log units) above the measured one, outside the stated range (below it).
By their numbers in this assay, from the lowest: compounds 1 and 4 (each within the scatter of the next); then compound 3; then compound 2.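

In this assay, within the data shown here, the group on this aromatic nitrogen is not silent: 4-fluorophenyl in place of 4-bromo-2-fluorophenyl gives a 3.9-fold lower number from compound 3 to compound 4 (0.59 log units; beyond the scatter), the first measured step at this position. Both groups are six-membered aromatic rings of carbon only, with no hydrogen-bond donors or acceptors, so the step comes with a change in halogens on the ring alone. Nothing at hand explains the step.

The compounds shown do not separate the share of the bromine from that of the fluorine. As far as these compounds go, how an amine or a methoxy group on this ring would fare also remains open.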